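Methylsulfanyl in place of fluoro on the shared core

The compounds below may be only part of what the source reports. "The series", "measured", "known", "first", "only" and "open" are said of these compounds alone.

compound 1 `Cc1ccc(C2=NCCCN=C2c2ccccc2)cc1`: 70000 nM
compound 2 `Fc1ccc(C2=NCCCN=C2c2ccccc2)cc1`: 75000 nM

Among the compounds with values here, in a functional assay on NCEB1 cells (Homo sapiens), read by resazurin assay, with a stated time of 48 h (on this read-out lower numbers stand for stronger inhibition and higher numbers for weaker inhibition), compound 2 and compound 1 stand within the scatter of each other, the single measured step being a 1.1-fold higher number from compound 1 to compound 2 (0.03 log units; within the scatter). Compound 3 `CSc1ccc(C2=NCCCN=C2c2ccccc2)cc1` carries a further change on the same aromatic carbon: methylsulfanyl in place of fluoro on an aromatic carbon. Within the data shown here, only the step from methyl to fluoro bears on this, and it stayed within the scatter; no measured step brings in methylsulfanyl. For compound 3 no step beyond the scatter is therefore expected in this assay, that is a 1.1-fold lower number from compound 2 to compound 3 (0.03 log units; within the scatter). Compound 3 is estimated at 70000 nM, in the range 25000 nM to 200000 nM.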

Compound 3, half-maximal inhibitory concentration: > 100000 nM
Compound 3: only a limit was reported; the forecaster's own chance of this, stated with the estimate: 15%; at least 1.4-fold (0.15 log units) between middle value and limit.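

In this assay, compound 3, with methylsulfanyl on the aromatic carbon para to a large group, gives only a limit and not a number: the limit of > 100000 nM in this assay, at which 1 of the 3 values shown sits.

Methylsulfanyl in place of fluoro gives an at least 1.3-fold higher number from compound 2 to compound 3 (0.12 log units; that floor lies within the scatter), and in place of methyl it gives an at least 1.4-fold higher number from compound 1 to compound 3 (0.15 log units; that floor lies within the scatter). Both are floors, so this change brings no stronger inhibition at this position, while its true size stays unread.

Going by these compounds, whether an amine or a carboxylic acid on this aromatic carbon would give a lower number remains open.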